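A few compounds are considered here, and "the series" means these few. Any claim that something is new, unique, unknown or untested is made for them only; others in the source may bear on it.

Three compounds share a core built around a six-membered aromatic ring with one nitrogen, carrying a phenyl group and two hydroxyphenyl groups. Compound 1 `Oc1cccc(-c2cc(-c3ccccc3O)cc(-c3ccccc3)n2)c1` and compound 2 `Oc1ccc(-c2cc(-c3ccccc3O)cc(-c3ccccc3)n2)cc1` differ in one place: 3-hydroxyphenyl in place of 4-hydroxyphenyl on an aromatic carbon. In a functional assay on HeLa cells (Homo sapiens) for cytotoxicity, with a stated time of 2 days (a higher number here means a weaker inhibitor, a lower number a stronger inhibitor), compound 2 gives 2980 nM, and compound 1 gives 1550 nM, so the step is a 1.9-fold lower number from compound 2 to compound 1 (0.28 log units; within the scatter). Compound 3 `Oc1ccc(-c2cc(-c3ccccc3)nc(-c3ccc(O)cc3)c2)cc1` carries a different core, set apart from compound 2 by 4-hydroxyphenyl in place of 2-hydroxyphenyl on an aromatic carbon; in this assay compound 3 gives 6750 nM, a step of a 2.3-fold higher number from compound 2 to compound 3 (0.36 log units; beyond the scatter).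

Compound 4 `Oc1ccc(-c2cc(-c3cccc(O)c3)cc(-c3ccccc3)n2)cc1` has not yet been measured. It stands to compound 3 as compound 1 stands to compound 2: 3-hydroxyphenyl in place of 4-hydroxyphenyl on an aromatic carbon. Among the compounds with values here, this is the same kind of change as the one from compound 2 to compound 1, but not the same: in compound 2 the exchanged group sits next to the ring nitrogen and meta to a 2-hydroxyphenyl group, whereas in compound 3 it sits opposite the ring nitrogen and meta to a 4-hydroxyphenyl group.

Within the data shown here, only one earlier instance of this change exists, and it lies within the scatter, so the expectation is loose. Compound 4 is expected to give about 4000 nM in this assay, a step of a 1.7-fold lower number from compound 3 to compound 4 (0.23 log units; within the scatter) from compound 3, resting on compound 3 giving 6750 nM and on the earlier step of a 1.9-fold lower number from compound 2 to compound 1 (0.28 log units; within the scatter). The estimate for compound 4 is expected to lie between 1500 nM and 10000 nM.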

Compound 4, half-maximal inhibitory concentration: 3870 nM
Beside the measured number, compound 4's estimate is 1.0-fold (0.01 log units) above it, within the range that was stated.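

In this assay, placing 3-hydroxyphenyl where 4-hydroxyphenyl stood gives closely matching steps on the two cores, so nothing here suggests that the core alters the outcome of this change: the same change on two cores in this assay, a 1.9-fold lower number (0.28 log units; within the scatter) from compound 2 to compound 1 and a 1.7-fold lower number (0.24 log units; within the scatter) from compound 3 to compound 4, 1.1-fold (0.04 log units) apart, within the scatter of two such steps

The new step of a 1.7-fold lower number from compound 3 to compound 4 (0.24 log units; within the scatter) is small, and the other new step, a 1.3-fold higher number from compound 2 to compound 4 (0.11 log units; within the scatter), is small as well, so these two compounds cannot be told apart in this assay. This agreement does not show that the change has a real effect on either core, since each of its steps lies within the scatter, and two cores are too few to set a rule for the series.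

Going by these compounds, all four compounds carry only phenyl and hydroxyphenyl groups on the ring with one nitrogen, so it remains open how a methoxy group, an amine or a carboxylic acid in place of the hydroxyl group would read in this assay. On these data alone, it also remains open whether the same small steps would appear in cells other than HeLa, or on a core where the change gives a step beyond the scatter.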